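The source may hold more compounds than are shown below. What is called first, only, known or untested is meant among the compounds shown, and "the series" means these compounds.

In a functional assay on A549 cells (Homo sapiens) for inhibition, read by MTT assay, with a stated time of 48 h (a higher number here means a weaker inhibitor, a lower number a stronger inhibitor), compound 1 `O=C(CC1CCOCC1)Nc1ccc(N2CCN(c3ccc(OC[C@@H]4CO[C@@](Cn5cncn5)(c5ccc(Cl)cc5Cl)O4)cc3)CC2)cc1` gives 10000 nM, and compound 2 `O=C(CCCCc1ccccc1)Nc1ccc(N2CCN(c3ccc(OC[C@@H]4CO[C@@](Cn5cncn5)(c5ccc(Cl)cc5Cl)O4)cc3)CC2)cc1` gives 2610 nM, the lower of the two numbers measured; the only step shown between them is a 3.8-fold lower number from compound 1 to compound 2 (0.58 log units; beyond the scatter). Compound 3 `O=C(CCCc1ccccc1)Nc1ccc(N2CCN(c3ccc(OC[C@@H]4CO[C@@](Cn5cncn5)(c5ccc(Cl)cc5Cl)O4)cc3)CC2)cc1` differs from compound 2 by phenyl in place of benzyl on a saturated chain carbon, three bonds along the chain from a carbonyl carbon, so the aromatic ring stays and only the chain length moves. For the measured compounds named here, no measured step bears directly on this change; the step from compound 1 to compound 2 concerned a different exchange and was modest. Compound 3 is therefore expected to stay close to compound 2, with a small step, a 1.3-fold higher number from compound 2 to compound 3 (0.13 log units; within the scatter). In this assay compound 3 is estimated at 3500 nM, within 1500 nM to 9000 nM.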

Compound 3, half-maximal inhibitory concentration: 3780 nM
Compound 3: the middle estimate sits 1.1-fold (0.03 log units) below what was measured, and the stated range covers the measured number.
By their numbers in this assay, from the lowest: compounds 2 and 3 (each within the scatter of the next); then compound 1.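

In this assay, phenyl in place of benzyl on a saturated chain carbon gives a 1.4-fold higher number from compound 2 to compound 3 (0.16 log units; within the scatter), so compound 2 and compound 3 cannot be told apart and this chain length can vary by this much without a readable difference. The gain over the oxan-4-yl group also holds with the phenethyl group, at a 2.6-fold lower number from compound 1 to compound 3 (0.42 log units; beyond the scatter), which compound 2 alone could not show. Nothing measured here gives a reason for these numbers. Still open, as far as these compounds go, is how a chain longer than 4-phenylbutyl, or an amine or a carboxylic acid in place of the phenyl ring, would read in this assay.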